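Methoxy for Fluoro on a Methylated Amine Core

The compounds below may be only part of what the source reports. "The series", "measured", "known", "first", "only" and "open" are said of these compounds alone.

Measured so far:
Compound 1, `Fc1ccc(C2=CC3CNCC(C2)C3)cn1`: 136%
Compound 2, `CN1CC2C=C(c3ccc(F)nc3)CC(C2)C1`: 9.4%

In an in vitro functional assay on SH-EP1 cells for agonist activity at Neuronal acetylcholine receptor; alpha4/beta2 (Homo sapiens), read by FLIPR and calcium flux (on this read-out higher numbers stand for larger maximal responses and lower numbers for smaller maximal responses), compound 2 gives 9.4%, the lowest of the two numbers seen so far. For the measured compounds named here, its only neighbour is compound 1, and the step of a number 126.6 percentage points lower from compound 1 to compound 2 (beyond the scatter) is large and beyond the scatter; it came from a methyl in place of hydrogen on an amine nitrogen in a ring, nothing else.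

Compound 3, `COc1ccc(C2=CC3CC(C2)CN(C)C3)cn1`, keeps that methylated amine and differs from compound 2 only on the aromatic ring: methoxy in place of fluoro on an aromatic carbon. Going by the values given here, no measured step touches this part of the structure, so the single step known, a number 126.6 percentage points lower from compound 1 to compound 2 (beyond the scatter), cannot guide it. Without any bearing data, the expectation for compound 3 is a step of about a number 2.6 percentage points higher from compound 2 to compound 3 (within the scatter), that is, none beyond the scatter. Compound 3 is therefore estimated at 12%, within a range from 0% to 40%.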

Compound 3, largest response reached (reported as percent of maximum), in percent of the reference or control that the assay uses: 20%
For compound 3 the middle estimate is 8 percentage points below the measured one; the range from low to high includes it.
By their numbers in this assay, from the lowest: compound 2; then compound 3; then compound 1.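

In this assay, the aromatic ring position next to the ring nitrogen turns out to respond to substitution: methoxy in place of fluoro gives a number 10.6 percentage points higher from compound 2 to compound 3 (beyond the scatter). For the compounds shown here, that modest step is the first measured change at this position, and it comes with the methyl kept on the amine nitrogen, the place where the earlier step was large, a number 126.6 percentage points lower from compound 1 to compound 2 (beyond the scatter). Nothing available here explains why the response moves with this swap.

From the compounds shown here alone, it remains open whether methoxy in place of fluoro would give a step of similar size on the core of compound 1, which has a hydrogen on that amine nitrogen. Also open, going by these compounds, is how other groups at this position would behave, such as an amine, a chlorine atom or a longer chain like ethoxy.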